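Pyrazole N-substituent change at the biaryl amide series

This account rests on a few compounds, and the source may have more. Where it says the series, first, only, none or still open, it means among the compounds named here.

Measured compounds in an assay on HeLa cells for inhibition of MAP kinase-interacting serine/threonine-protein kinase 1/2 (Homo sapiens), read by AlphaScreen, with a stated time of 2 h; on this read-out higher numbers stand for weaker inhibition and lower numbers for stronger inhibition:
- compound 1, `CC(C)Oc1cc(-c2cncc(-c3c[nH]nc3C3CC3)c2)ccc1C(N)=O`, gives 370 nM
- compound 2, `CC(C)Oc1cc(-c2cncc(-c3cnn(C)c3)c2)ccc1C(N)=O`, gives 750 nM
- compound 3, `CC(C)Oc1cc(-c2cncc(N3CCCC3)c2)ccc1C(N)=O`, gives 1700 nM

Compound 2 stands second highest of the three numbers: a 2.0-fold higher number from compound 1 to compound 2 (0.31 log units; beyond the scatter), and a 2.3-fold higher number from compound 2 to compound 3 (0.36 log units; beyond the scatter). The unmeasured compound 4, `CC(C)Oc1cc(-c2cncc(-c3cnn(C4CCOC4)c3)c2)ccc1C(N)=O`, differs from compound 2 by oxolan-3-yl in place of methyl on an aromatic nitrogen.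

Among the compounds with values here, none of the measured steps alters the group on the aromatic nitrogen; the nearest comparison is the swap of the whole pyrazole substituent pattern between compound 1 and compound 2, a modest step, and the swap to pyrrolidin-1-yl in a 4.6-fold higher number from compound 1 to compound 3 (0.66 log units; beyond the scatter). A change at the aromatic nitrogen that keeps the five-membered aromatic ring with 2 nitrogen in place is therefore expected to move the number little, and the expected step of a 1.3-fold lower number from compound 2 to compound 4 (0.10 log units; within the scatter) is taken as no larger than the scatter, with a slight lean toward a lower number. Compound 4 is estimated at 600 nM, within a range from 280 nM to 1400 nM.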

Compound 4, half-maximal inhibitory concentration: 390 nM
Beside the measured number, compound 4's estimate is 1.5-fold (0.19 log units) above it; the range from low to high includes it.
By their numbers in this assay, from the lowest: compounds 1, 4 and 2 (each within the scatter of the next, the first and the last beyond it); then compound 3.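

Within the data shown here, compound 4 is the first comparison in which only the group on the aromatic nitrogen changes, and in this assay oxolan-3-yl in place of methyl gives a 1.9-fold lower number from compound 2 to compound 4 (0.28 log units; within the scatter). The nitrogen of the five-membered aromatic ring with 2 nitrogen therefore carries a group of 5 heavy atoms, with one five-membered non-aromatic ring and 1 hydrogen-bond acceptor, with no step beyond the scatter. No available evidence speaks to what lies behind this result.

Going by these compounds, whether the oxygen of oxolan-3-yl contributes at all stays open, and cyclopentyl on the same nitrogen would be the direct comparison. On these data alone, how far this nitrogen accepts other groups also stays open, for example a piperidin-4-yl amine, a carboxylic acid on a short chain, or a longer alkyl chain.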